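Replacing a 3-aminophenyl by a 4-(dimethylamino)phenyl

The source may report more compounds than this note shows. Statements on the series, on what has been measured and on what is new or still open speak of the compounds shown alone.

Compound 1 `CCCS(=O)(=O)Nc1ccc(F)c(C(=O)c2n[nH]c3ncc(-c4ccccc4Cl)cc23)c1F` and compound 2 `CCCS(=O)(=O)Nc1ccc(F)c(C(=O)c2n[nH]c3ncc(-c4cccc(N)c4)cc23)c1F` share one core and differ only in the aryl group attached to it. In an assay for binding affinity to dual specificity mitogen-activated protein kinase kinase 4 (Homo sapiens), read by KINOMEscan, tested at 100 nM (a lower number here means a stronger effect, a higher number a weaker effect of the compound at the concentration tested), compound 1 gives 9.3%, and compound 2 gives 1.6%. Within the data shown here, compound 2 thus holds the smaller of the two numbers, yet the single step of a number 7.7 percentage points lower from compound 1 to compound 2 (within the scatter) stays within the usual scatter, so the two results cannot be told apart.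

Compound 3 `CCCS(=O)(=O)Nc1ccc(F)c(C(=O)c2n[nH]c3ncc(-c4ccc(N(C)C)cc4)cc23)c1F` is not yet measured. It differs from compound 2 by 4-(dimethylamino)phenyl in place of 3-aminophenyl on an aromatic carbon. Among the measured compounds shown here, the only comparable step, from compound 1 to compound 2, changed the same aryl group and produced a difference within the scatter. On that basis a step of roughly a number 2.4 percentage points higher from compound 2 to compound 3 (within the scatter) is expected, with no change beyond the scatter. For compound 3 the estimated result in this assay is 4%, with a likely range from 0.5% to 18%.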

Compound 3, a percentage reported as activity, at one concentration (the size of the read-out at that concentration, not a potency): 2.5%
Beside the measured number, compound 3's estimate is 1.5 percentage points above it; the measured number falls inside the stated range.
By their numbers in this assay, from the lowest: compounds 2, 3 and 1 (each within the scatter of the next).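

In this assay, the change to 4-(dimethylamino)phenyl gives a number 0.9 percentage points higher from compound 2 to compound 3 (within the scatter), and measured against the 2-chlorophenyl group it gives a number 6.8 percentage points lower from compound 1 to compound 3 (within the scatter), so all three aryl groups at this position read alike. What is new is that the hydrogen-bond donor of the 3-aminophenyl group is not needed for a reading in this range, since 4-(dimethylamino)phenyl has none. No measurement shown here explains why these groups give such similar readings.

Going by these compounds, it remains open whether a much larger or charged group, such as a carboxylic acid on the phenyl ring or a morpholine ring in place of the dimethylamino group, would stay in this range. A reading at a single concentration also leaves open whether these compounds would differ in potency across a range of concentrations.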